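The source may hold more compounds than are shown below. What is called first, only, known or untested is meant among the compounds shown, and "the series" means these compounds.

In an ADME assay on CCRF-HSB-2 cells (Homo sapiens) for cytotoxicity, with a stated time of 7 days (a higher number here means that more compound is tolerated, a lower number that less compound is tolerated), three compounds sharing one core have been measured. Compound 1 `Nc1nc(OCC(F)(F)F)c2ncn(/C=C3/CC3(CO)CO)c2n1` gives > 20000 nM, which is a limit of the assay. Compound 2 `CC(C)CSc1nc(N)nc2c1ncn2/C=C1/CC1(CO)CO` gives an actual number, 60000 nM. Compound 3 `Nc1nc(N2CCCC2)c2ncn(/C=C3/CC3(CO)CO)c2n1` gives > 20000 nM, also a limit. Compound 3 thus stands at the limit of > 20000 nM in this assay, at which 2 of the 3 values shown sit, with no number of its own.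

Compound 4 `CSc1nc(N)nc2c1ncn2/C=C1/CC1(CO)CO` has methylsulfanyl in place of pyrrolidin-1-yl on an aromatic carbon. The measured changes at this carbon give no size to carry over: there is a step that the two limits leave unreadable from compound 1 to compound 3, then a step that the limit leaves unreadable from compound 2 to compound 3, and also a step that the limit leaves unreadable from compound 1 to compound 2. The closest guide is compound 2, which also has a sulfanyl group at this carbon and gives 60000 nM. On that single value, no firm direction can be expected in this assay, and the change is expected to leave compound 4 well tolerated. The estimated change is a step that the limit leaves unreadable from compound 3 to compound 4. Compound 4 is expected at 40000 nM, with an estimated range of 12000 nM to 100000 nM.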

Compound 4, half-maximal cytotoxic concentration: > 100000 nM
Compound 4 was reported as a limit (the forecaster's own chance of this, stated with the estimate: 55%); middle value at least 2.5-fold (0.39 log units) away from the limit.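

In this assay compound 4 is reported only as a limit, the highest one among the compounds shown: the limit of > 100000 nM in this assay, at which 1 of the 4 values shown sits. For the compounds shown here, with hydrogen in place of isopropyl on the saturated chain carbon bound to the sulfur, the two sulfanyl compounds give the first readable step at this aromatic carbon, an at least 1.6-fold higher number from compound 2 to compound 4 (0.22 log units; that floor lies within the scatter), but only a floor is known, so the step does not firmly separate them. The steps from compound 1 and compound 3 to compound 4 cannot be read, so methylsulfanyl cannot be sized against 2,2,2-trifluoroethoxy or pyrrolidin-1-yl.

As far as these compounds go, it remains open how far the true value of compound 4 lies past its limit, and whether the length of the sulfanyl chain matters at all. Also open, from the compounds shown here alone, is how an ethylsulfanyl group or a primary amine at this carbon would read in this assay.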